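Methoxycarbonyl on the triazene nitrogen of compound 3

The source may report more compounds than this note shows. Statements on the series, on what has been measured and on what is new or still open speak of the compounds shown alone.

Compound 3 `O=[N+]([O-])c1ccc(/N=N/Nc2ccc([N+](=O)[O-])cc2Cl)c(Cl)c1` gives 3010 nM in a functional assay on HeLa cells (Homo sapiens) for cytotoxicity, read by MTT assay, with a stated time of 72 h (on this read-out higher numbers stand for weaker inhibition and lower numbers for stronger inhibition), the highest of the three numbers measured. Going by the values given here, compound 1 `O=C(c1ccccc1)N(/N=N/c1ccc([N+](=O)[O-])cc1Br)c1ccc([N+](=O)[O-])cc1Br` gives 1530 nM, and compound 2 `O=C(c1cccc(C(F)(F)F)c1)N(/N=N/c1ccc([N+](=O)[O-])cc1Br)c1ccc([N+](=O)[O-])cc1Br` gives 1120 nM; both carry an acyl group on the central nitrogen and bromine where compound 3 carries chlorine, so no single step links either of them to compound 3. Among the compounds with values here, the one measured step, a 1.4-fold lower number from compound 1 to compound 2 (0.14 log units; within the scatter), concerns a substituent on the acyl ring and does not touch the change now in question. Compound 4 `COC(=O)N(/N=N/c1ccc([N+](=O)[O-])cc1Cl)c1ccc([N+](=O)[O-])cc1Cl` differs from compound 3 by methoxycarbonyl in place of hydrogen on a nitrogen on an aromatic ring. The values of compound 1 and compound 2 show that acylated analogues sit at lower numbers than compound 3, but with two differences at once this gives only a loose hint. Compound 4 is therefore expected to show a step of a 1.7-fold lower number from compound 3 to compound 4 (0.22 log units; within the scatter), not clearly beyond the scatter. The estimate for compound 4 is 1800 nM, with a range from 700 nM to 4500 nM.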

Compound 4, half-maximal inhibitory concentration: 980 nM
Compound 4: middle estimate off by 1.8-fold (0.26 log units), on the high side, within the range that was stated.
By their numbers in this assay, from the lowest: compounds 4, 2, 1 and 3 (each within the scatter of the next, the first and the last beyond it).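

In this assay, methoxycarbonyl in place of hydrogen on a nitrogen on an aromatic ring gives a 3.1-fold lower number from compound 3 to compound 4 (0.49 log units; beyond the scatter), a modest step beyond the scatter. The earlier compounds shown here could offer only a loose hint about this position, since their acyl groups came together with bromine in place of chlorine; here the chlorine stays and the change at this nitrogen stands alone. It shows that the hydrogen on this nitrogen can be replaced without a loss on this read-out, though nothing available explains the step.

The compounds shown leave open whether the step belongs to methoxycarbonyl itself or would also appear with a longer chain such as ethoxycarbonyl, or with acetyl or an amine-bearing carbamoyl group. They also leave open what chlorine and bromine contribute when everything else is kept the same.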